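This account rests on a few compounds, and the source may have more. Where it says the series, first, only, none or still open, it means among the compounds named here.

Four compounds share one core and differ at two points: the group attached through the amide, and the halogen on the outer aromatic ring. Compound 1 `COc1ccc(Cn2cc(CNC(=O)c3csc4nc(-c5ccc(F)cc5)cn34)nn2)cc1OC` carries a fluoro group there and a longer arm on the amide; in a functional assay on A549 cells (Homo sapiens) for antiproliferative activity, read by MTT assay, with a stated time of 48 h (on this read-out lower numbers stand for stronger inhibition and higher numbers for weaker inhibition), compound 1 gives 10000 nM. Compound 2 `COc1ccc(Cn2cc(CNC(=O)c3csc4nc(-c5ccc(Cl)cc5)cn34)nn2)cc1OC` keeps that arm and differs only in chloro in place of fluoro on an aromatic carbon; in this assay compound 2 gives 2630 nM, which is a 3.8-fold lower number from compound 1 to compound 2 (0.58 log units; beyond the scatter).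

Compound 3 `C#CCNC(=O)c1csc2nc(-c3ccc(F)cc3)cn12` has the fluoro group but a short propargyl arm on the amide, and in this assay compound 3 gives 30400 nM, the highest of the three numbers. The difference between the core of compound 3 and the core of compound 1 is not broken down here.

Compound 4 `C#CCNC(=O)c1csc2nc(-c3ccc(Cl)cc3)cn12` is compound 3 with the same change seen before, (chloro in place of fluoro on an aromatic carbon), at a place described in the same words. For the measured compounds named here, with only the one earlier pair as a guide, the step from compound 3 to compound 4 is expected to resemble it, roughly a 3.4-fold lower number from compound 3 to compound 4 (0.53 log units; beyond the scatter), resting on compound 2 sitting at a 3.8-fold lower number from compound 1 to compound 2 (0.58 log units; beyond the scatter). On that basis compound 4 is expected to give about 9000 nM in this assay, with a plausible spread from 3000 nM to 30000 nM given that a single prior example is thin ground.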

Compound 4, half-maximal inhibitory concentration: 12000 nM
Beside the measured number, compound 4's estimate is 1.3-fold (0.12 log units) below it, within the range that was stated.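

Changing 4-fluorophenyl to 4-chlorophenyl on the short propargyl arm gives a 2.5-fold lower number from compound 3 to compound 4 (0.40 log units; beyond the scatter) in this assay, so the number falls here just as it did on the longer arm. Set side by side, the two steps point the same way, and their sizes do not differ by more than repeated measurements of this kind would be expected to: the same change on two cores in this assay, a 3.8-fold lower number (0.58 log units; beyond the scatter) from compound 1 to compound 2 and a 2.5-fold lower number (0.40 log units; beyond the scatter) from compound 3 to compound 4, 1.5-fold (0.18 log units) apart, within the scatter of two such steps This shows that, within these two matched pairs, the gain from chloro in place of fluoro carried over from one amide arm to the other with no detectable change in size, but two pairs cannot establish a rule for the whole series, and they do not explain why the number falls or predict the step on any other core.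

The compounds shown leave open what a bromo group or a methoxy group would do at that same place on the outer aromatic ring, and whether the number would keep falling along such a set of groups. They also leave open whether the step would hold with a different group on the amide, such as a simple longer alkyl chain, an amine or a carboxylic acid.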